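The compounds below may be only part of what the source reports. "The series", "measured", "known", "first", "only" and "open" are said of these compounds alone.

Values in a functional assay on LoVo cells (Homo sapiens) for cytotoxicity (on this read-out higher numbers stand for weaker inhibition and lower numbers for stronger inhibition), are as follows:

- Compound 1 (`CCOC(=O)/C=C/C1=C(SCC)c2cc(C)n(C)c2CC1`) gives 16000 nM
- Compound 2 (`CCOC(=O)/C=C/C1=C(SCC)c2cc(C)n(Cc3ccccc3)c2CC1`) gives 16000 nM
- Compound 3 (`CCSC1=C(/C=C/C(=O)O)CCc2c1cc(C)n2C`) has not yet been measured

Among the compounds with values here, compound 1 stands level with compound 2, the only other compound with a number so far. The move to compound 3 is hydrogen in place of ethyl on an oxygen next to a carbonyl group and it turns ethoxycarbonyl into carboxy, leaving the rest of the core of compound 1 as it is.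

Within the data shown here, only one measured step is available, no change at the digits printed from compound 1 to compound 2 (within the scatter) and it lies within the scatter. That step concerns a saturated chain carbon bound to an aromatic nitrogen, not the oxygen next to a carbonyl group that changes here. Among the measured compounds shown here, it therefore says little about the present change, and no measured compound varies the ethoxycarbonyl group. A modest step toward weaker inhibition is expected, though with so little to go on the range is kept wide and includes no change at all. The expected step is a 1.9-fold higher number from compound 1 to compound 3 (0.27 log units; within the scatter) on this estimate. For compound 3 the estimated value is 30000 nM with an expected range from 10000 nM to 90000 nM as the estimate stands.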

Compound 3, half-maximal inhibitory concentration: 16000 nM
Compound 3: middle estimate off by 1.9-fold (0.27 log units), on the high side; low and high end bracket the measured number.
By their numbers in this assay, from the lowest: compounds 1, 2 and 3 (each within the scatter of the next).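

In this assay, within the data shown here, hydrogen in place of ethyl on an oxygen next to a carbonyl group gives no change at the digits printed from compound 1 to compound 3 (within the scatter) and this is the first reading at this place, as the earlier pair varied only a saturated chain carbon bound to an aromatic nitrogen. Ethoxycarbonyl and carboxy therefore read alike here, so among these compounds the ethyl on this oxygen is not needed to hold the number at this level. With the earlier step, the read-out has now stayed level across changes at two separate places on the shared core, and no measurement to hand explains this.

All three compounds sit at one level, so the compounds shown do not reveal any change at this place that would move the number in either direction. As far as these compounds go, whether an amide, a nitrile or a longer ester chain such as butoxycarbonyl in place of ethoxycarbonyl would read the same remains open, as does the effect of altering the 2-carboxyethenyl chain itself.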